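Predicting a Difluorobenzyl Ester from Three Measured Analogues

The compounds below may be only part of what the source reports. "The series", "measured", "known", "first", "only" and "open" are said of these compounds alone.

Compound 1, `COC(=O)C1=C(C)NC(C)=C(C(=O)OCC(C)[N+](=O)[O-])C1c1cccc([N+](=O)[O-])c1`: 108 nM
Compound 2, `COC(=O)C1=C(C)NC(C)=C(C(=O)OCc2ccccc2)C1c1cccc([N+](=O)[O-])c1`: 25 nM
Compound 3, `COC(=O)C1=C(C)NC(C)=C(C(=O)OC2C=CCCC2)C1c1cccc([N+](=O)[O-])c1`: 10 nM

All three measured compounds share one core and differ only in the group carried on an oxygen next to a carbonyl group. In a functional assay on HEK293 cells for antagonist activity at Voltage-dependent L-type calcium channel subunit alpha-1C (Oryctolagus cuniculus), read by FLIPR (a higher number here means a weaker inhibitor, a lower number a stronger inhibitor), compound 1 gives 108 nM, compound 2 gives 25 nM, and compound 3 gives 10 nM. Compound 3 has the lowest number of the three, and because both a 2.5-fold lower number from compound 2 to compound 3 (0.40 log units; beyond the scatter) and an 11-fold lower number from compound 1 to compound 3 (1.03 log units; beyond the scatter) lie beyond the scatter, it is the strongest inhibitor shown so far.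

Compound 4, `COC(=O)C1=C(C)NC(C)=C(C(=O)OCc2ccc(F)c(F)c2)C1c1cccc([N+](=O)[O-])c1`, has not yet been measured. It differs from compound 3 in one place: 3,4-difluorobenzyl in place of cyclohex-2-en-1-yl on an oxygen next to a carbonyl group. The step that bears most directly on this change is a 2.5-fold lower number from compound 2 to compound 3 (0.40 log units; beyond the scatter), since compound 2 carries benzyl in the same place; read backwards, leaving cyclohex-2-en-1-yl for benzyl raised the number modestly. For the measured compounds named here, no measured step tells what the two fluorines add, so that part remains open. The expectation is therefore a modest rise from compound 3, a 2.0-fold higher number from compound 3 to compound 4 (0.30 log units; within the scatter), landing near compound 2. Compound 4 is expected to give 20 nM, within a range from 6 nM to 60 nM.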

Compound 4, half-maximal inhibitory concentration: 7 nM
Estimate against measurement, compound 4: 2.9-fold (0.46 log units) above, and the stated range covers the measured number.
By their numbers in this assay, from the lowest: compounds 4 and 3 (each within the scatter of the next); then compound 2; then compound 1.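

The two fluorines now have a measured effect: in this assay, placing them on the benzyl group lowers the number beyond the scatter (a 3.6-fold lower number from compound 2 to compound 4 (0.55 log units; beyond the scatter)). The step between the two ring types stays within the scatter (a 1.4-fold lower number from compound 3 to compound 4 (0.15 log units; within the scatter)), so at this oxygen the aromatic 3,4-difluorobenzyl and the non-aromatic cyclohex-2-en-1-yl cannot be told apart, even though plain benzyl fell short of cyclohex-2-en-1-yl. The distance from the nitro-bearing ester of compound 1 also grows (a 15-fold lower number from compound 1 to compound 4 (1.19 log units; beyond the scatter)), which widens the span of numbers seen at this one position.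

On these data alone, whether a benzyl group carrying a single fluorine, or an ester bearing an amine or a longer chain, would read the same stays open. Nothing available here explains why any of these steps has the size it has.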